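Swapping a Methoxy for a tert-Butoxycarbonyl Group

A few compounds are considered here, and "the series" means these few. Any claim that something is new, unique, unknown or untested is made for them only; others in the source may bear on it.

For the measured compounds named here, compound 2 `COCOc1ccc(CN(Cc2ccc(C(C)(C)C)cc2)Cc2cc3cc(C)ccc3[nH]c2=O)cc1` is the only compound here with an actual number: in a toxicity assay on MDCK cells (Canis lupus familiaris) for cytotoxicity, read by crystal violet staining, with a stated time of 48 h (a lower number here means that less compound is tolerated, a higher number that more compound is tolerated), compound 2 gives 6400 nM. Compound 1 `Cc1ccc2[nH]c(=O)c(CN(Cc3ccccc3)Cc3ccc(C(C)(C)C)cc3)cc2c1` gives > 5000 nM, which is a limit of the assay rather than a number. Compound 3 `CCc1ccc2[nH]c(=O)c(CN(Cc3ccc(OCOC)cc3)Cc3ccc(C(C)(C)C)cc3)cc2c1` gives > 10000 nM, also a limit. The step that the limit leaves unreadable from compound 1 to compound 2 thus cannot be sized, while an at least 1.5-fold higher number from compound 2 to compound 3 (0.19 log units; that floor lies within the scatter) has a floor that sits within the scatter. Compound 4 `Cc1ccc2[nH]c(=O)c(CN(Cc3ccc(OCC(=O)OC(C)(C)C)cc3)Cc3ccc(C(C)(C)C)cc3)cc2c1` differs from compound 2 by tert-butoxycarbonyl in place of methoxy on a saturated chain carbon bound to an oxygen on an aromatic ring. Neither measured step touches this part of the molecule, so no change beyond the scatter is expected in either direction. The estimate for compound 4 in this assay is 6400 nM, with a range from 2500 nM to 16000 nM. The step this implies, no change at the digits printed from compound 2 to compound 4 (within the scatter), is an expectation, not a measurement.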

Compound 4, half-maximal cytotoxic concentration: > 10000 nM
Compound 4: no number, only a limit; the forecaster's own chance of this, stated with the estimate: 40%; at least 1.5-fold (0.19 log units) between middle value and limit.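

At this position, on a saturated chain carbon bound to an oxygen on an aromatic ring, tert-butoxycarbonyl can replace methoxy without the number in this assay falling. Compound 4 gives only a limit of the assay, not a number: the limit of > 10000 nM in this assay, at which 2 of the 4 values shown sit.

The comparison with compound 2 shows an at least 1.5-fold higher number from compound 2 to compound 4 (0.19 log units; that floor lies within the scatter), and the step from compound 1 cannot be read. Going by these compounds, the true size of the step stays open, and so does the outcome of putting a carboxylic acid or an amine at this place.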